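This account rests on a few compounds, and the source may have more. Where it says the series, first, only, none or still open, it means among the compounds named here.

Measured compounds:
compound 1 `O=C([C@@H]1CCCN(S(=O)(=O)c2ccc(S(=O)(=O)N3CC[C@@H](O)C3)cc2)C1)N1CCC(F)(F)CC1` — 330 nM
compound 2 `CCN(CC)S(=O)(=O)c1ccc(S(=O)(=O)N2CCC[C@@H](C(=O)N3CCC(C(F)(F)F)CC3)C2)cc1` — 370 nM

In a functional assay on BXPC-3 cells (Homo sapiens) for inhibition, read by MTT assay, with a stated time of 7 days (a higher number here means a weaker inhibitor, a lower number a stronger inhibitor), compound 1 gives 330 nM and compound 2 gives 370 nM; the two numbers fall within the usual scatter of each other, so compound 1 stands together with compound 2 rather than apart from it. Compound 3 `CN(C)S(=O)(=O)c1ccc(S(=O)(=O)N2CCC[C@@H](C(=O)N3CCC(F)(F)CC3)C2)cc1` has not yet been measured. It differs from compound 1 in one place: dimethylamino in place of 3-hydroxypyrrolidin-1-yl on a sulfonyl sulfur. For the measured compounds named here, no measured pair shows this change directly, so no step beyond the scatter is expected in this assay, in either direction. Compound 3 is therefore expected to give about 350 nM, between 150 nM and 800 nM, which is a step of a 1.1-fold higher number from compound 1 to compound 3 (0.03 log units; within the scatter).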

Compound 3, half-maximal inhibitory concentration: 560 nM
The estimate for compound 3 lay 1.6-fold (0.20 log units) below the measured number; measured number inside the range.
By their numbers in this assay, from the lowest: compounds 1, 2 and 3 (each within the scatter of the next).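

In this assay, for the compounds shown here, this place on the sulfonyl sulfur is tested directly for the first time, and dimethylamino in place of 3-hydroxypyrrolidin-1-yl gives a 1.7-fold higher number from compound 1 to compound 3 (0.23 log units; within the scatter). For this pair, then, the ring, the hydroxyl and the defined stereocentre can all leave without a step beyond the scatter. No measured evidence bears on this result. The compounds shown leave open whether unsubstituted pyrrolidin-1-yl, morpholine or piperazine on the same sulfur would also stay within the scatter. They also do not separate the contribution of the hydroxyl from that of the ring.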